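The source may report more compounds than this note shows. Statements on the series, on what has been measured and on what is new or still open speak of the compounds shown alone.

In an ADME assay on MT4 cells (Homo sapiens) for cytotoxicity (on this read-out higher numbers stand for lower toxicity in this test and lower numbers for higher toxicity in this test), compound 1 `COC(=O)N[C@H](C(=O)NN(CCC[C@@](O)(Cc1ccccc1)C(=O)N[C@H]1c2ccccc2C[C@H]1O)Cc1ccc(-c2ccccn2)cc1)C(C)(C)C` gives only a limit, > 10000 nM. Compound 2 `COC(=O)N[C@H](C(=O)NN(CCC[C@@](O)(Cc1ccccc1)C(=O)N[C@H]1c2ccccc2C[C@H]1O)Cc1ccc(-c2noc(C)n2)cc1)C(C)(C)C` likewise gives only a limit, > 10000 nM. Compound 3 `COC(=O)N[C@H](C(=O)NN(CCC[C@@](O)(Cc1ccccc1)C(=O)N[C@H]1c2ccccc2C[C@H]1O)Cc1ccc(-c2csc(C)n2)cc1)C(C)(C)C` also gives only a limit, > 10000 nM, so it stands level with the others on (the limit of > 10000 nM in this assay, at which 3 of the 3 values shown sit).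

Compound 4 `COC(=O)N[C@H](C(=O)NN(CCC[C@@](O)(Cc1ccccc1)C(=O)N[C@H]1c2ccccc2C[C@H]1O)Cc1ccc(-c2ccccc2)cc1)C(C)(C)C` differs from compound 3 as follows: phenyl in place of 2-methyl-1,3-thiazol-4-yl on an aromatic carbon. In words, this is phenyl in place of 2-methyl-1,3-thiazol-4-yl on an aromatic carbon.

Three measured swaps of this group bear on the change: a step that the two limits leave unreadable from compound 1 to compound 2, a step that the two limits leave unreadable from compound 1 to compound 3 and a step that the two limits leave unreadable from compound 2 to compound 3. None of them has a readable size, so they point to no direction.

The expected change is no more than the usual scatter, for a step that the limit leaves unreadable from compound 3 to compound 4. For compound 4 the estimated value is 12000 nM, with an expected range of 5000 nM to 30000 nM.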

Compound 4, half-maximal cytotoxic concentration: 7500 nM
Beside the measured number, compound 4's estimate is 1.6-fold (0.20 log units) above it, within the range that was stated.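

Phenyl at this position gives the first actual number in this assay, whereas the pyridin-2-yl, 5-methyl-1,2,4-oxadiazol-3-yl and 2-methyl-1,3-thiazol-4-yl groups gave only limits: the limit of > 10000 nM in this assay, at which 3 of the 4 values shown sit.

The change to phenyl gives an at least 1.3-fold lower number from compound 3 to compound 4 (0.12 log units; that floor lies within the scatter), an at least 1.3-fold lower number from compound 2 to compound 4 (0.12 log units; that floor lies within the scatter) and an at least 1.3-fold lower number from compound 1 to compound 4 (0.12 log units; that floor lies within the scatter), and these floors alone establish no real difference, although the true steps could be larger.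

Going by these compounds, the true size of each step remains open. So does what an amine or a carboxylic acid at this position would give in this assay.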